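The source may hold more compounds than are shown below. What is called first, only, known or untested is meant among the compounds shown, and "the series" means these compounds.

Compound 3 `Cc1nn(-c2ccccc2)c2ncc(CCCO)cc12` gives 19% in a functional assay on THP-1 cells (Homo sapiens) for inhibition, read by ELISA, tested at 10 uM (on this read-out lower numbers stand for less inhibition and higher numbers for more inhibition at the one concentration tested (going by the name of the read-out)), and stands lowest of the three numbers seen, although the gap to compound 1 is within the scatter. Compound 1 `Cc1nn(C)c2ncc(CCCO)cc12` gives 27%, while compound 2 `COC[C@H](O)[C@@H](OC)[C@@H](OC)C1=CC2C(C)=NN(C)C2N=C1` gives 35%, a number beyond the scatter from compound 3. Compound 4 `COc1ccc(-c2nn(-c3ccccc3)c3ncc(CCCO)cc23)cc1` differs from compound 3 in one place: 4-methoxyphenyl in place of methyl on an aromatic carbon. Within the data shown here, the only measured step, a number 8 percentage points lower from compound 1 to compound 3 (within the scatter), put phenyl in place of methyl on an aromatic nitrogen, a different group at a different place, so it bears only loosely on this change, and it stayed within the scatter. A step within the scatter is therefore expected, a number 1 percentage points higher from compound 3 to compound 4 (within the scatter). Compound 4 is estimated at 20%, in a range from 5% to 40%.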

Compound 4, a percentage reported as inhibition, at one concentration (the size of the read-out at that concentration, not a potency): 36%
For compound 4 the middle estimate is 16 percentage points below the measured one; the range from low to high includes it.
By their numbers in this assay, from the lowest: compounds 3, 1, 2 and 4 (each within the scatter of the next, the first and the last beyond it).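

Swapping methyl for 4-methoxyphenyl on this aromatic carbon comes with a number 17 percentage points higher from compound 3 to compound 4 (beyond the scatter) in this assay. This is the first listed change in one place to go beyond the scatter, and it shows that this carbon can carry a group of eight heavy atoms instead of one without losing inhibition at the one concentration tested. No measurement at hand speaks to why the number rose. Open, on these data alone, is whether plain phenyl or an amine on this carbon would do the same, and whether the rise holds with methyl on the aromatic nitrogen.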